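Methoxy to Propylsulfanyl: An Expected Return of Activity

The source may hold more compounds than are shown below. What is called first, only, known or untested is meant among the compounds shown, and "the series" means these compounds.

Of the compounds shown here, two sharing one core have been tested in an in vitro functional assay on 1321-N1 cells for agonist activity at P2Y purinoceptor 4 (Homo sapiens), read by scintillation proximity assay and inositol phosphate accumulation; on this read-out lower numbers stand for an effect already at smaller amounts and higher numbers for an effect only at larger amounts of compound. Compound 1 `CCSc1nc(=O)ccn1[C@@H]1O[C@H](COP(=O)(O)O)[C@@H](O)[C@H]1O` carries an ethylsulfanyl group and in this assay gives 4330 nM. Compound 2 `COc1nc(=O)ccn1[C@@H]1O[C@H](COP(=O)(O)O)[C@@H](O)[C@H]1O` carries a methoxy group in the same place. In this assay compound 2 reaches only a limit of the measurement, > 100000 nM, so no number is known for it. The step of an at least 23-fold higher number from compound 1 to compound 2 (1.36 log units; beyond the scatter) is thus known only as a lower bound, and the limit of > 100000 nM in this assay, at which 1 of the 2 values shown sits, marks where compound 2 sits. Compound 3 `CCCSc1nc(=O)ccn1[C@@H]1O[C@H](COP(=O)(O)O)[C@@H](O)[C@H]1O` has not yet been measured. It differs from compound 2 by propylsulfanyl in place of methoxy on an aromatic carbon. Within the data shown here, the only measured step that bears on this change runs from compound 1 to compound 2: it was large and carried the number beyond the measurable range. Compound 3 moves in the opposite direction, exchanging the methoxy for a propylsulfanyl chain akin to the ethylsulfanyl of compound 1. A large drop in the number is therefore expected, an at least 28-fold lower number from compound 2 to compound 3 (1.45 log units; beyond the scatter). Compound 3 is estimated at 3500 nM, with a range from 800 nM to 25000 nM.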

Compound 3, half-maximal effective concentration: > 100000 nM
Compound 3: only a limit was reported; the forecaster's own chance of this, stated with the estimate: 10%; middle value at least 28-fold (1.45 log units) from the limit.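

In this assay compound 3 gives only a limit of the assay, > 100000 nM, and not a number. Adding a single methyl to the ethylsulfanyl chain, on the saturated chain carbon two bonds along the chain from the sulfur, gives an at least 23-fold higher number from compound 1 to compound 3 (1.36 log units; beyond the scatter), so a sulfur-linked chain at this place does not by itself ensure a measurable effect, and the outcome depends on the chain as well as on the linking atom. Compound 2 and compound 3 both end at a limit, which leaves the step between them unreadable, and only compound 1 keeps a number, as the series now shows: the limit of > 100000 nM in this assay, at which 2 of the 3 values shown sit.

On these data alone, it remains open whether a shorter methylsulfanyl group would give a number at this place, and whether a longer chain such as butylsulfanyl would stay at the limit. Equally open, as far as these compounds go, is how an amine in the same place would read out, and with compound 2 and compound 3 both at a limit, nothing orders the two.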